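Chain length at the acid in a naphthonitrile-pyridine series

A few compounds are considered here, and "the series" means these few. Any claim that something is new, unique, unknown or untested is made for them only; others in the source may bear on it.

Measured compounds:
compound 1 `N#Cc1ccc(Nc2cnccc2SCCCC(=O)O)c2ccccc12` — 2780 nM
compound 2 `N#Cc1ccc(Oc2cnccc2SCCCCCCC(=O)O)c2ccccc12` — 3780 nM
compound 3 `CN(c1cnccc1SCCCC(=O)O)c1ccc(C#N)c2ccccc12` — 2580 nM

In an assay on HEK293 cells for inhibition of solute carrier family 22 member 12 (Homo sapiens), read by scintillation counting, with stated times of 30 min and 15 min (on this read-out lower numbers stand for stronger inhibition and higher numbers for weaker inhibition), compound 1 gives 2780 nM and stands second highest of the three numbers. Among the compounds with values here, its nearest neighbour is compound 3, which in this assay gives 2580 nM; the one step with a single change, a 1.1-fold lower number from compound 1 to compound 3 (0.03 log units; within the scatter), is methyl in place of hydrogen on a nitrogen on an aromatic ring. Within the data shown here, compound 2, which in this assay gives 3780 nM, differs from compound 1 in two places, an oxygen in place of the ring nitrogen and a longer acid chain, so its gap to compound 1 shows only that both changes together stay within the scatter.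

Compound 4 `N#Cc1ccc(Nc2cnccc2SCCCCC(=O)O)c2ccccc12` is not yet measured. It differs from compound 1 by carboxymethyl in place of carboxy on a saturated chain carbon, three bonds along the chain from a sulfur. Among the measured compounds shown here, no measured pair isolates this change. The nearest bearing is compound 2, whose longer chain together with the linker change leaves the number close to compound 1. Compound 4 is therefore expected to lie near compound 1, with a 1.1-fold higher number from compound 1 to compound 4 (0.03 log units; within the scatter) not beyond the scatter. The estimate for compound 4 in this assay is 3000 nM, ranging from 1200 nM to 7500 nM.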

Compound 4, half-maximal inhibitory concentration: 2280 nM
Estimate against measurement, compound 4: 1.3-fold (0.12 log units) above, within the range that was stated.
By their numbers in this assay, from the lowest: compounds 4, 3, 1 and 2 (each within the scatter of the next).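

Within the data shown here, the pair of compound 1 and compound 4 gives the first reading of chain length at the acid on its own, with the amine link to the core held fixed: in this assay there is a 1.2-fold lower number from compound 1 to compound 4 (0.09 log units; within the scatter) for carboxymethyl in place of carboxy on a saturated chain carbon, three bonds along the chain from a sulfur. Compound 2 had offered only a longer chain combined with an oxygen in place of the ring nitrogen, so it could not show what the chain did alone, whereas here the added carbon is the only difference and the two numbers cannot be told apart. Why this position tolerates the change remains unexplained, as nothing on hand bears on the result.

Still open, on these data alone, is whether a shorter chain, or an amide or a tetrazole in place of the carboxylic acid, would move the number beyond the scatter on the shared core. The longer chain of compound 2 also remains to be read on the amine-linked core, and the 4-carboxybutyl chain on the oxygen-linked or N-methyl-linked core, before the chain and the link can be treated as independent.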